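A few compounds are considered here, and "the series" means these few. Any claim that something is new, unique, unknown or untested is made for them only; others in the source may bear on it.

Two compounds share one core and differ only at an aromatic carbon of a six-membered aromatic ring of carbon only, para to a large group. Compound 1 `COc1cccc(OC)c1C(=O)Nc1nnc(-c2ccc(C(C)C)cc2)s1` carries an isopropyl there, and in a functional assay on the whole organism (integument) for inhibition, with Chilo suppressalis as the target, read by scintillation counting, with a stated time of 72 h (a higher number here means a weaker inhibitor, a lower number a stronger inhibitor), compound 1 gives 398 nM. Compound 2 `COc1cccc(OC)c1C(=O)Nc1nnc(-c2ccc([N+](=O)[O-])cc2)s1` carries a nitro at that carbon, and in this assay compound 2 gives 355 nM. The step of a 1.1-fold lower number from compound 1 to compound 2 (0.05 log units; within the scatter) shows that exchanging these two groups left the number within the scatter. Compound 2 thus stands with the lowest of the two numbers, but compound 1 lies so close that no order between the two can be read.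

Compound 3 `COc1cccc(OC)c1C(=O)Nc1nnc(-c2ccc(C#N)cc2)s1` has not yet been measured. It differs from compound 2 by cyano in place of nitro on an aromatic carbon. Among the compounds with values here, the only measured step at this position, a 1.1-fold lower number from compound 1 to compound 2 (0.05 log units; within the scatter), bears on it and was small. On that basis the expected step in this assay is a 1.1-fold higher number from compound 2 to compound 3 (0.05 log units; within the scatter), none beyond the scatter. Compound 3 is therefore estimated at 400 nM, with a range from 150 nM to 1100 nM.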

Compound 3, half-maximal inhibitory concentration: 209 nM
For compound 3 the middle estimate is 1.9-fold (0.28 log units) above the measured one; the measured number falls inside the stated range.
By their numbers in this assay, from the lowest: compounds 3, 2 and 1 (each within the scatter of the next).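

Cyano at this carbon gives a 1.7-fold lower number from compound 2 to compound 3 (0.23 log units; within the scatter) and a 1.9-fold lower number from compound 1 to compound 3 (0.28 log units; within the scatter) in this assay, so the comparison now covers three groups rather than one pair. The earlier pair showed only that isopropyl and nitro could not be told apart at this aromatic carbon, para to a large group. Cyano now joins them: all three pairs among compound 1, compound 2 and compound 3 lie within the scatter, so this assay gives no order among the groups, and the exchange of nitro for cyano, though it differs in the group's atoms and bond type, does not separate the two compounds. Nothing given here offers a reason for these numbers.

The compounds shown leave open whether this carbon stays as undemanding with an amine, a carboxylic acid or a longer alkyl chain in place of these three groups, any of which might move the number beyond the scatter. They also leave open how the number responds to a change elsewhere in the shared core, such as a hydroxyl in place of a methoxy group, since all three compounds keep that part unchanged.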